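Removing the Chloro Group from a Nitro Analogue

The source may report more compounds than this note shows. Statements on the series, on what has been measured and on what is new or still open speak of the compounds shown alone.

In an in vitro assay on cells for inhibition of Amine oxidase [flavin-containing] A (Homo sapiens), read by Amplex Red, with a stated time of 15 min, tested at 100 uM (a lower number here means less inhibition, a higher number more inhibition at the concentration tested (going by the name of the read-out)), compound 1 `COc1ccc(/C=C/C=C/C(=O)c2ccccc2O)cc1` gives 40%, a moderate degree of inhibition at the tested concentration. Compound 2 `O=C(/C=C/C=C/c1ccc([N+](=O)[O-])cc1)c1cc(Cl)ccc1O` differs from compound 1 in more than one place, so only the two read-outs can be compared: in this assay compound 2 is reported as "not active" (no number reported), with no number reported, so it cannot be placed on the same scale and stands simply as reported. Compound 3 `O=C(/C=C/C=C/c1ccc([N+](=O)[O-])cc1)c1ccccc1O` has not yet been tested. The change from compound 2 to compound 3 is hydrogen in place of chloro on an aromatic carbon. Among the measured compounds shown here, no measured step of this kind is available, so the expected size of the move in this assay rests on compound 2 alone, and only a small rise, if any, is anticipated. Compound 3 is expected to give about 15% in this assay, within a range from 0% to 40%.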

Compound 3, a percentage reported as inhibition, at one concentration (the size of the read-out at that concentration, not a potency): "not active" (no number reported)
Compound 3 has no reported number here, so the estimate cannot be set against anything.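

Among the compounds shown here, compound 2 and compound 3 are both reported without a number, so no step between them can be read, and no measured evidence bears on this result. These compounds leave open whether replacing chloro with hydrogen changes inhibition of this enzyme at all.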